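A few compounds are considered here, and "the series" means these few. Any claim that something is new, unique, unknown or untested is made for them only; others in the source may bear on it.

In a functional assay on MDA-MB-231 cells (Homo sapiens) for antiproliferative activity, with a stated time of 48 h (a higher number here means a weaker inhibitor, a lower number a stronger inhibitor), the series reads as follows:

compound 1 `CCOC(=O)c1ccc(-c2ccc(N(C)C)nn2)cc1` gives > 25000 nM as a limit
compound 2 `COC(=O)c1ccc(-c2ccc(N(C)C)nn2)cc1` gives > 25000 nM as a limit
compound 3 `CN1CCN(c2ccc(-c3cccc(C(F)(F)F)c3)nn2)CC1` gives > 25000 nM as a limit

Compound 1 has no numerical value here, only a limit. The same holds across the series, with the limit of > 25000 nM in this assay, at which 3 of the 3 values shown sit, as the common position of all three compounds.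

Compound 4 `CCOC(=O)c1ccc(-c2ccc(OC(C)C)nn2)cc1` comes from compound 1 by one change: isopropoxy in place of dimethylamino on an aromatic carbon while the rest of the molecule stays the same. Among the measured compounds shown here, the one measured step, a step that the two limits leave unreadable from compound 1 to compound 2 and lies at the other end of the molecule, so it gives no size to carry over. For the measured compounds named here, compound 3 supplies no step for this change either.

The expectation therefore rests on compound 1 with its limit of > 25000 nM as the only anchor. No step beyond the scatter is expected in this assay and another reading at the limit is likely.

The estimated change is a number no higher from compound 1 to compound 4 (the limit leaves the size open) and no clear direction is expected.

For compound 4 the expected value is 25000 nM with an estimated range from 10000 nM to 50000 nM as its ends.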

Compound 4, half-maximal inhibitory concentration: > 25000 nM
Compound 4 ended at the assay's limit; the forecaster's own chance of this, stated with the estimate: 70%; the middle value lies on the limit itself.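

No new step can be read between compound 1 and compound 4, since each stands only at a limit in this assay: the limit of > 25000 nM in this assay, at which 4 of the 4 values shown sit.
The compounds shown leave open how isopropoxy and dimethylamino compare on this core, and which change, if any, would give a numerical value.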